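The compounds below may be only part of what the source reports. "The series", "measured", "known", "first", "only" and "open" are said of these compounds alone.

Compound 1, `COc1cc(O)c(C=O)c2c1[C@H](OC)C[C@@H](c1ccccc1)O2`: 90 nM
Compound 2, `COc1c(C)c(O)c(C=O)c2c1[C@H](O)C[C@@H](c1ccccc1)O2`: 80 nM

Both compounds were measured in an assay on cells for inhibition of Aromatase (Homo sapiens), with a stated time of 30 min; on this read-out higher numbers stand for weaker inhibition and lower numbers for stronger inhibition. Compound 2 gives 80 nM, and compound 1 stands within the scatter of it at 90 nM, so neither can be set apart from the other. Compound 3, `COc1c(C)c(O)c(C=O)c2c1[C@H](OC)C[C@@H](c1ccccc1)O2`, has not yet been measured. It differs from compound 2 by methyl in place of hydrogen on an oxygen on a saturated carbon. Among the compounds with values here, no step between measured compounds covers this change. Compound 1 already carries methoxy on an oxygen on a saturated carbon and gives 90 nM, so no step beyond the scatter is expected in this assay. Compound 3 is expected to give 80 nM, between 40 nM and 160 nM. The expected step is no change at the digits printed from compound 2 to compound 3 (within the scatter).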

Compound 3, half-maximal inhibitory concentration: 150 nM
Estimate against measurement, compound 3: 1.9-fold (0.27 log units) below, within the range that was stated.
By their numbers in this assay, from the lowest: compounds 2, 1 and 3 (each within the scatter of the next).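

In this assay, within the data shown here, methyl in place of hydrogen on the oxygen on a saturated carbon gives a 1.9-fold higher number from compound 2 to compound 3 (0.27 log units; within the scatter), the first reading of this change between two measured compounds. With methoxy held at that place, methyl in place of hydrogen on an aromatic carbon gives a 1.7-fold higher number from compound 1 to compound 3 (0.22 log units; within the scatter), so neither single change can be told apart from the scatter. No measurement is available that bears on the reason for these steps. The compounds shown leave open whether an amine or a longer chain such as butoxy at that saturated carbon would step beyond the scatter. They also leave open whether hydroxy and methoxy would read alike without the aromatic methyl.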